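From 4-hydroxyphenyl to 3,4-dimethoxyphenyl in a cell toxicity test

This account rests on a few compounds, and the source may have more. Where it says the series, first, only, none or still open, it means among the compounds named here.

Measured so far in an ADME assay on HEK293 cells (Homo sapiens) for cytotoxicity, read by MTT assay, with a stated time of 48 h; on this read-out lower numbers stand for stronger inhibition and higher numbers for weaker inhibition
Compound 1 `O=C1CS/C(=N/c2ccccc2)N1Cc1ccncc1` gives 99500 nM
Compound 2 `O=C1/C(=C\c2ccc(O)cc2)S/C(=N/c2ccccc2)N1Cc1ccncc1` gives 142000 nM

Compound 2 lies within the usual scatter of compound 1, so these two numbers cannot be told apart. Compound 3 `COc1ccc(/C=C2/S/C(=N/c3ccccc3)N(Cc3ccncc3)C2=O)cc1OC` arises from compound 2 by one change, 3,4-dimethoxyphenyl in place of 4-hydroxyphenyl on a double-bonded chain carbon bound to a double-bonded ring carbon with 3,4-dimethoxyphenyl in place of 4-hydroxyphenyl on a double-bonded chain carbon bound to a double-bonded ring carbon. Compound 2 with 142000 nM sits close to compound 1 with 99500 nM and gives no ground for expecting a large move. The expected 1.2-fold lower number from compound 2 to compound 3 (0.07 log units; within the scatter) stays within the scatter in this assay and leans slightly towards a lower number. Compound 3 is estimated at 120000 nM (range 50000 nM to 250000 nM).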

Compound 3, half-maximal inhibitory concentration: 171000 nM
Compound 3: the middle estimate sits 1.4-fold (0.15 log units) below what was measured; measured number inside the range.
By their numbers in this assay, from the lowest: compounds 1, 2 and 3 (each within the scatter of the next).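

In this assay, putting 3,4-dimethoxyphenyl in place of 4-hydroxyphenyl on a double-bonded chain carbon bound to a double-bonded ring carbon gives a 1.2-fold higher number from compound 2 to compound 3 (0.08 log units; within the scatter). At this position, then, the read-out does not separate these two groups, even though the entering group has 10 heavy atoms against 7 and 0 hydrogen-bond donors against 1. On these data alone, whether an amine or a carboxylic acid on this aromatic ring would give a step beyond the scatter stays open. Nothing at hand speaks to why these two groups cannot be told apart.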